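A few compounds are considered here, and "the series" means these few. Any claim that something is new, unique, unknown or untested is made for them only; others in the source may bear on it.

Measured compounds:
compound 1 `COc1ccccc1COc1ccc(-c2cc(CN3CCN(Cc4ccc(C(F)(F)F)cc4)CC3)no2)cc1` gives 300 nM in a functional assay on MCF7 cells (Homo sapiens) for antiproliferative activity, read by sulforhodamine B assay, with a stated time of 72 h; a higher number here means a weaker inhibitor, a lower number a stronger inhibitor
compound 2 `N#Cc1cccc(COc2ccc(-c3cc(CN4CCN(c5ccc(C(F)(F)F)cc5)CC4)no3)cc2)c1` gives 2000 nM in this assay

Of the two numbers shown, compound 2 stands at the top: its value in this assay is the higher one, and compound 1, the nearest, sits well below it, with a gap that lies beyond the usual scatter. Going by the values given here, the two compounds differ in several places at once, so no single step between them is counted here; their values simply show that compound 2 is the weaker inhibitor of the pair.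

Compound 3 `N#Cc1cccc(COc2ccc(-c3cc(CN4CCN(c5ccc(F)cc5)CC4)no3)cc2)c1` is not yet measured. It departs from compound 2 in one place: fluoro in place of trifluoromethyl on an aromatic carbon. Among the compounds with values here, no measured pair in this set shows the effect of that change, so the expectation rests on the change alone, which removes three heavy atoms from the aryl on the piperazine and leaves the rest of compound 2 untouched. A small step is expected for a 1.3-fold lower number from compound 2 to compound 3 (0.12 log units; within the scatter), with no direction that can be called clearly beyond the scatter. For compound 3 the estimate in this assay is 1500 nM, within a range from 600 nM to 4000 nM.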

Compound 3, half-maximal inhibitory concentration: 2400 nM
Compound 3: middle estimate off by 1.6-fold (0.20 log units), on the low side; measured number inside the range.
By their numbers in this assay, from the lowest: compound 1; then compounds 2 and 3 (each within the scatter of the next).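

Fluoro in place of trifluoromethyl gives a 1.2-fold higher number from compound 2 to compound 3 (0.08 log units; within the scatter) in this assay, the first change in one place that can be read in this set. At this position, on an aromatic carbon of a six-membered aromatic ring of carbon only and para to a large group, the exchange of 4-(trifluoromethyl)phenyl for 4-fluorophenyl therefore leaves the antiproliferative read-out within the scatter, even though the entering group has 1 heavy atom and the leaving group has 4. No measurement on hand bears on why these two groups give values that cannot be told apart.

The compounds shown leave open whether this position would stay as insensitive with a group of another kind, such as an amine, a carboxylic acid or a longer alkyl chain, since only trifluoromethyl and fluoro stand there so far. Going by these compounds alone, they also leave open which of the several differences between compound 2 and compound 1 goes with the value of 300 nM for compound 1, as no step in one place connects that compound to the others.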